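This account rests on a few compounds, and the source may have more. Where it says the series, first, only, none or still open, it means among the compounds named here.

Compound 1 `COc1ccc(Br)cc1Nc1cc(NC(=O)Nc2c(Cl)cccc2Cl)ncn1` has the lowest of three numbers in a functional assay on PC-9 cells (Homo sapiens) for inhibition, read by MTT assay, with a stated time of 48 h, tested at 10 uM (on this read-out higher numbers stand for more inhibition at the one concentration tested (going by the name of the read-out) and lower numbers for less inhibition), where compound 1 gives 69%. Compound 2 `COc1cc(NC(=O)Nc2cc(Nc3cc(Br)ccc3OC)ncn2)cc(OC)c1` gives 82.5% in this assay, and compound 3 `COc1cc(Nc2cc(NC(=O)Nc3c(Cl)cccc3Cl)ncn2)cc(OC)c1` gives 90%, the value furthest above compound 1 and beyond the scatter. For the measured compounds named here, the one measured step, a number 13.5 percentage points higher from compound 1 to compound 2 (beyond the scatter), concerns the amide-type nitrogen and not the aromatic-ring nitrogen, so it does not bear directly on compound 4 `Cc1ccc(Nc2cc(NC(=O)Nc3c(Cl)cccc3Cl)ncn2)cc1C`; the change from compound 1 to compound 4 is 3,4-dimethylphenyl in place of 5-bromo-2-methoxyphenyl on a nitrogen on an aromatic ring. Only the values of compound 1 and compound 3 show that replacing the aryl group on that ring nitrogen can raise inhibition. Compound 4 is therefore expected to give 75% in this assay, between 55% and 90%, an estimated step of a number 6 percentage points higher from compound 1 to compound 4 (within the scatter).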

Compound 4, a percentage reported as inhibition, at one concentration (the size of the read-out at that concentration, not a potency): 92.1%
The estimate for compound 4 lay 17.1 percentage points below the measured number; measured number outside the range, above it.
By their numbers in this assay, from the lowest: compound 1; then compounds 2, 3 and 4 (each within the scatter of the next).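

The step of a number 23.1 percentage points higher from compound 1 to compound 4 (beyond the scatter) shows that, in this assay, the aryl group on a nitrogen on an aromatic ring can be changed with a clear gain in a single exchange. The entering 3,4-dimethylphenyl holds carbon only, so neither bromine nor oxygen on this ring is needed for high inhibition at the one concentration tested. No measurement given here bears on why the number rises. The compounds shown leave open which part of the exchange, the bromine, the methoxy or the two methyls, carries the step. They also leave open how an amine or a carboxylic acid on this ring would read.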